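A fluorophenyl swap at the assay limit

The source may report more compounds than this note shows. Statements on the series, on what has been measured and on what is new or still open speak of the compounds shown alone.

Measured in a physicochemical assay for lipophilicity, at pH 7.4; on this read-out higher numbers stand for higher lipophilicity and lower numbers for lower lipophilicity:

- Compound 1 `Cc1cc(N[C@H](CCCCN)C(=O)NO)cc(C)c1F`: < 3
- Compound 2 `COc1ccc(CNCCCC[C@@H](Nc2cc(C)c(F)c(C)c2)C(=O)NO)cc1`: < 3
- Compound 3 `Cc1cc(N[C@H](CCCCNCc2ccc(C(F)(F)F)cc2)C(=O)NO)cc(C)c1F`: < 3

Each entry is a limit of the assay and not a number. Compound 3 stands at the limit of < 3 in this assay, at which 3 of the 3 values shown sit, so it shares its position with compound 1 and compound 2, and no order among the three can be read.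

Compound 4 `Cc1cc(N[C@H](CCCCNCCCc2ccc(F)cc2)C(=O)NO)cc(C)c1F` has not yet been measured. It differs from compound 3 by 2-(4-fluorophenyl)ethyl in place of 4-(trifluoromethyl)phenyl on a saturated chain carbon bound to an amine nitrogen.

The closest measured changes are a step that the two limits leave unreadable from compound 1 to compound 2 and a step that the two limits leave unreadable from compound 2 to compound 3. Neither gives a size, so neither gives a direction to carry over, and no shift beyond the usual scatter is expected in this assay. The expected step is a step that the limit leaves unreadable from compound 3 to compound 4. This expectation rests on compound 3, whose < 3 is a limit. Compound 4 is estimated at 2.5, with an expected range of 1.8 to 3.1.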

Compound 4, distribution coefficient: < 3
Compound 4 was reported as a limit; the forecaster's own chance of this, stated with the estimate: 85%; the middle value is on the limit's open side.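

In this assay, among these compounds, compound 4 is again reported only as a limit, so no step among compound 1, compound 2, compound 3 and compound 4 can be read: the limit of < 3 in this assay, at which 4 of the 4 values shown sit. The compounds shown leave open where the four actual values lie and whether the different groups on the amine nitrogen shift them at all.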